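Aryl urea series: halogen pattern swap on the amide nitrogen

The source may hold more compounds than are shown below. What is called first, only, known or untested is meant among the compounds shown, and "the series" means these compounds.

Working notes. Among the measured compounds shown here, compound 2 `O=C(Nc1cccc(CNc2nccnc2Cl)c1)Nc1ccc(Cl)cc1Br` gives 6720 nM in a functional assay on HepG2 cells (Homo sapiens) for antiproliferative activity, read by MTT assay, with a stated time of 48 h (a higher number here means a weaker inhibitor, a lower number a stronger inhibitor), the lowest of the three numbers so far, though compound 3 `CCc1ccc(NC(=O)Nc2cccc(CNc3nccnc3Cl)c2)c(CC)c1` at 10800 nM and compound 1 `Cc1ccc(NC(=O)Nc2cccc(CNc3nccnc3Cl)c2)cc1` at 11500 nM both sit within the scatter of it. Compound 4 `O=C(Nc1cccc(CNc2nccnc2Cl)c1)Nc1ccc(F)c(Cl)c1` differs from compound 2 by 3-chloro-4-fluorophenyl in place of 2-bromo-4-chlorophenyl on an amide-type nitrogen. For the measured compounds named here, the only measured step touching this position is a 1.7-fold lower number from compound 1 to compound 2 (0.23 log units; within the scatter), so exchanging one substituted phenyl for another on this nitrogen has so far moved the number by no more than the scatter. On that basis no step beyond the scatter is expected in this assay, in either direction, which would mean a 1.1-fold higher number from compound 2 to compound 4 (0.05 log units; within the scatter). Compound 4 is therefore estimated at 7500 nM, with a range of 3500 nM to 16000 nM.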

Compound 4, half-maximal inhibitory concentration: 6750 nM
The estimate for compound 4 lay 1.1-fold (0.05 log units) above the measured number; the measured number falls inside the stated range.
By their numbers in this assay, from the lowest: compounds 2, 4, 3 and 1 (each within the scatter of the next).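

Replacing 2-bromo-4-chlorophenyl with 3-chloro-4-fluorophenyl on the amide-type nitrogen gives, in this assay, (a 1.0-fold higher number from compound 2 to compound 4 (0.00 log units; within the scatter)), and the same group in place of 4-methylphenyl gives (a 1.7-fold lower number from compound 1 to compound 4 (0.23 log units; within the scatter)). A different halogen pair, with bromine gone and fluorine present, therefore stays within the scatter of both earlier groups at this position. No measurement bears on why these numbers stay together.

From the compounds shown here alone, whether a phenyl carrying a carboxylic acid or an amine, rather than only halogens or alkyl groups, would stay within the scatter remains open.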